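Swapping Chloro for Trifluoromethyl on the Shared Core

The source may report more compounds than this note shows. Statements on the series, on what has been measured and on what is new or still open speak of the compounds shown alone.

Of the compounds shown here, two have so far been tested in a functional assay on CHO cells for antagonist activity at prostaglandin E2 receptor EP3 subtype (Homo sapiens), read by FLIPR, with a stated time of 1 h; a higher number here means a weaker inhibitor, a lower number a stronger inhibitor. Compound 1 `CC1(c2ccc(-c3ccc4ccccc4c3)[nH]c2=O)CNC(=O)O1` gives 79.4 nM. For the measured compounds named here, compound 2 `CC(C)C1(c2cc(Cl)c(-c3ccc4ccccc4c3)[nH]c2=O)OC(=O)NC1=O` gives 50.1 nM, a number that lies within the scatter of the one for compound 1, so the two cannot be ranked. Compound 3 `CC(C)C1(c2cc(C(F)(F)F)c(-c3ccc4ccccc4c3)[nH]c2=O)OC(=O)NC1=O` differs from compound 2 in one place: trifluoromethyl in place of chloro on an aromatic carbon. Going by the values given here, no measured pair shows this particular change, so a small step in either direction, or none beyond the scatter, is plausible. Compound 3 is expected to give about 40 nM, with a range from 15 nM to 130 nM, which means an expected step of a 1.3-fold lower number from compound 2 to compound 3 (0.10 log units; within the scatter).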

Compound 3, inhibition constant: 631 nM
Compound 3: the middle estimate sits 16-fold (1.20 log units) below what was measured, and the stated range ends below it.
By their numbers in this assay, from the lowest: compounds 2 and 1 (each within the scatter of the next); then compound 3.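

In this assay, this position on the shared core proves sensitive to what sits on it: trifluoromethyl in place of chloro gives a 13-fold higher number from compound 2 to compound 3 (1.10 log units; beyond the scatter). Compound 1 and compound 2 could not show this, as they differ in more than one place. Nothing in the data bears on why the step is so large.

As far as these compounds go, with only chloro and trifluoromethyl compared at this aromatic carbon, it remains open how a methyl, a bromo or a nitrile would behave there, and whether any of them would match chloro.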